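Sulfonylpiperazine series: aryl swap on the sulfonyl sulfur

A few compounds are considered here, and "the series" means these few. Any claim that something is new, unique, unknown or untested is made for them only; others in the source may bear on it.

Measured compounds:
compound 1 `COc1cc2nc(N3CCN(S(=O)(=O)c4ccc(Cl)s4)CC3)nc(N)c2cc1OC` gives 25000 nM in a functional assay on PC-3 cells (Homo sapiens) for inhibition; on this read-out lower numbers stand for stronger inhibition and higher numbers for weaker inhibition
compound 2 `COc1cc2nc(N3CCN(S(=O)(=O)c4cccc(C(=O)O)c4)CC3)nc(N)c2cc1OC` gives 53000 nM

For the measured compounds named here, compound 2 stands at the weak end of the two numbers so far: the change a 2.1-fold higher number from compound 1 to compound 2 (0.33 log units; beyond the scatter) is the only measured step, and it runs toward weaker inhibition. Compound 3 `COc1cc2nc(N3CCN(S(=O)(=O)c4cc(C(=O)O)c(Cl)cc4Cl)CC3)nc(N)c2cc1OC` differs from compound 2 by 5-carboxy-2,4-dichlorophenyl in place of 3-carboxyphenyl on a sulfonyl sulfur. Going by the values given here, no measured step covers the addition of two chlorines to the carboxyphenyl, so the single step from compound 1 to compound 2 bears only loosely on it; it shows that exchanging the aryl group on the sulfonyl sulfur moves the read-out by a modest amount either way. The expectation for compound 3 is therefore a step of a 1.3-fold lower number from compound 2 to compound 3 (0.12 log units; within the scatter), near the scatter, leaning toward slightly stronger inhibition. Compound 3 is estimated at 40000 nM, with a range from 15000 nM to 100000 nM.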

Compound 3, half-maximal inhibitory concentration: 52000 nM
The estimate for compound 3 lay 1.3-fold (0.11 log units) below the measured number, within the range that was stated.
By their numbers in this assay, from the lowest: compound 1; then compounds 3 and 2 (each within the scatter of the next).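

In this assay adding the two chlorines to the carboxyphenyl group makes no difference beyond the scatter (a 1.0-fold lower number from compound 2 to compound 3 (0.01 log units; within the scatter)), so 5-carboxy-2,4-dichlorophenyl and 3-carboxyphenyl cannot be told apart on this sulfonyl sulfur. Set against 5-chlorothiophen-2-yl, the dichlorinated acid gives a step much like that of compound 2 (a 2.1-fold higher number from compound 1 to compound 3 (0.32 log units; beyond the scatter)), which places both carboxyphenyl compounds on the weaker side of compound 1 and shows that this gap survives the added chlorines. No available evidence accounts for either step.

The compounds shown leave open whether a methyl ester or a primary amide in place of the carboxylic acid would shift the read-out. Also open, as far as these compounds go, is whether a phenyl ring bearing chlorine without any carboxylic acid would match compound 1.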